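Compound 3: one step on from compound 2

The source may report more compounds than this note shows. Statements on the series, on what has been measured and on what is new or still open speak of the compounds shown alone.

Compound 1 `Nc1c(-c2nc3ccccc3[nH]2)cc(-c2ccccc2)n1-c1ccc(Cl)cc1`: 9900 nM
Compound 2 `Nc1c(-c2nc3ccccc3[nH]2)cc(-c2ccccc2)n1-c1nc2ccccc2[nH]1`: 7700 nM

In a functional assay on A549 cells (Homo sapiens) for cytotoxicity, read by resazurin assay, with a stated time of 72 h (a lower number here means a stronger inhibitor, a higher number a weaker inhibitor), compound 2 gives 7700 nM, which lies within the usual scatter of the value for compound 1. For the measured compounds named here, the only measured step, a 1.3-fold lower number from compound 1 to compound 2 (0.11 log units; within the scatter), exchanged 4-chlorophenyl for 1H-benzimidazol-2-yl on an aromatic nitrogen and stayed within the scatter.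

Compound 3 `Nc1c(-c2nc3ccccc3[nH]2)cc(-c2ccccc2)n1Cc1nc2ccccc2[nH]1` changes that same place: (1H-benzimidazol-2-yl)methyl in place of 1H-benzimidazol-2-yl on an aromatic nitrogen. In words, (1H-benzimidazol-2-yl)methyl stands in place of 1H-benzimidazol-2-yl on an aromatic nitrogen. Going by the values given here, no measured compound carries this group, so the evidence is thin, but the exchange behind compound 2 at this nitrogen left the number within the scatter. No clear direction is therefore expected in this assay. The expected change is a 1.1-fold lower number from compound 2 to compound 3 (0.04 log units; within the scatter), no step beyond the scatter. The estimate for compound 3 is 7000 nM, expected to fall between 3000 nM and 16000 nM.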

Compound 3, half-maximal inhibitory concentration: 5100 nM
Beside the measured number, compound 3's estimate is 1.4-fold (0.14 log units) above it; measured number inside the range.
By their numbers in this assay, from the lowest: compounds 3, 2 and 1 (each within the scatter of the next).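

In this assay, the new result gives a 1.5-fold lower number from compound 2 to compound 3 (0.18 log units; within the scatter), while the comparison with the 4-chlorophenyl compound gives a 1.9-fold lower number from compound 1 to compound 3 (0.29 log units; within the scatter). For the compounds shown here, compound 3 thus shows that this aromatic nitrogen, which had so far carried its 1H-benzimidazol-2-yl group directly, can also carry it through the methyl link of (1H-benzimidazol-2-yl)methyl without any step leaving the scatter, so all three substituents remain indistinguishable in this cytotoxicity measure. No supporting measurement is available to account for these small differences.

As far as these compounds go, it remains open whether a substituent of another kind at this nitrogen, such as a simple amine or a carboxylic acid at the end of a longer chain, would move the number beyond the scatter. The compounds shown also leave untested whether changing the phenyl group or the amino group on the shared core would do so.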